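The source may report more compounds than this note shows. Statements on the series, on what has been measured and on what is new or still open speak of the compounds shown alone.

In a functional assay on RXF 393 cells (Homo sapiens) for inhibition, read by sulforhodamine B assay, with a stated time of 48 h (a lower number here means a stronger inhibitor of growth, a higher number a weaker inhibitor of growth), compound 1 `Nc1cc(N)c2nc(-c3ccccc3)c(Oc3ccc(Cl)c(Cl)c3)nc2c1` gives 6030 nM. Two related compounds were measured alongside it: compound 2 `Nc1cc(N)c2nc(-c3ccccc3)c(NCc3ccc(Cl)c(Cl)c3)nc2c1` gives 3090 nM, and compound 3 `COc1cc(CNc2nc3cc(N)cc(N)c3nc2-c2ccccc2)cc(OC)c1OC` gives 7410 nM. Compound 1 thus falls between the other two numbers, yet each gap is within the scatter of repeated measurements, so the three compounds cannot be told apart in this assay.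

Compound 4 `Nc1cc(N)c2nc(-c3ccccc3)c(Sc3ccc(F)cc3)nc2c1` has not been measured. It differs from compound 1 by one change: (4-fluorophenyl)sulfanyl in place of 3,4-dichlorophenoxy on an aromatic carbon. Among the compounds with values here, no measured pair shows the effect of such a change. Since compounds 1, 2 and 3 all sit in a narrow band, compound 4 is expected to stay close to compound 1, with a step of a 1.0-fold lower number from compound 1 to compound 4 (0.00 log units; within the scatter) no larger than the scatter. The estimate for compound 4 is 6000 nM, within a range from 2500 nM to 15000 nM.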

Compound 4, concentration for 50% growth inhibition: < 100000 nM
Compound 4: only a limit was reported (the forecaster's own chance of this, stated with the estimate: 5%); the middle value lies beyond the limit too.
By their numbers in this assay, from the lowest: compounds 2, 1 and 3 (each within the scatter of the next, the first and the last beyond it).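

In this assay compound 4 gives < 100000 nM, which is a limit and not a number. So no step between compound 1 and compound 4 can be read. As far as these compounds go, whether (4-fluorophenyl)sulfanyl in place of 3,4-dichlorophenoxy changes growth inhibition stays open.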